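Notes on a trifluoromethoxy for fluoro exchange

A few compounds are considered here, and "the series" means these few. Any claim that something is new, unique, unknown or untested is made for them only; others in the source may bear on it.

Measured so far in a functional assay on PC-3 cells (Homo sapiens) for inhibition, read by MTT assay, with a stated time of 24 h, tested at 0.1 ug/mL; a higher number here means more inhibition of growth at the concentration tested, a lower number less inhibition of growth:
- compound 1 `O=C(CCCCC1CCSS1)Nc1ccc(OC(F)(F)F)cc1` gives 6.69%
- compound 2 `O=C(CCCCC(S)CCS)Nc1ccc(F)cc1` gives "not determined" (no result reported)

Compound 2 has no place on the scale of this assay, since no result was reported for it. Within the data shown here, the series therefore offers no measured step, and the single number available is the one for compound 1 at 6.69%.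

Compound 3 `O=C(CCCCC(S)CCS)Nc1ccc(OC(F)(F)F)cc1` has not yet been tested. The structural change under consideration is trifluoromethoxy in place of fluoro on an aromatic carbon, with trifluoromethoxy in place of fluoro on an aromatic carbon, para to a large group.

With no number for compound 2, the step cannot be sized directly from its starting point. Taking compound 1 at 6.69% as the only guide, the expectation in this assay is a reading close to that level, with no shift beyond the usual scatter and no favoured direction. This remains a weak basis, resting on one reading at one concentration.

For compound 3 the estimated growth inhibition is 10%, with an expected range from 1% to 25%.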

Compound 3, percent growth inhibition at one concentration: 14.9%
For compound 3 the middle estimate is 4.9 percentage points below the measured one, and the stated range covers the measured number.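

The series now holds one readable step: in this assay, a group of five heavy atoms with no ring in place of the group with a five-membered non-aromatic ring, on a saturated chain carbon, four bonds along the chain from a carbonyl carbon, gives a number 8.2 percentage points higher from compound 1 to compound 3 (within the scatter). With trifluoromethoxy on the aromatic ring, this exchange therefore does not separate the two compounds in this assay. The fluoro to trifluoromethoxy change itself cannot be read, as compound 2 carries no number, and nothing measured on these compounds bears on the result.

Open, on these data alone, is whether any group on the aromatic carbon, para to a large group, matters at all in this assay, since neither trifluoromethoxy nor fluoro has a readable step and a chloro, methoxy or trifluoromethyl group would be needed to show it. Also open is whether a longer chain between the carbonyl carbon and the sulfur-bearing group would move the reading beyond the scatter, given that the shown compounds share one chain and a single tested concentration.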